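The compounds below may be only part of what the source reports. "The series", "measured", "known", "first", "only" and "open" are said of these compounds alone.

Working notes on the anilide series built on the shared core of compound 1, `COc1ccc(OC)c(NC(=O)CCCCCCNC(=O)C(O)(O)C(F)(F)F)c1`. In a functional assay on HCT-116 cells (Homo sapiens) for inhibition, read by colorimetric assay, with a stated time of 3 days (on this read-out lower numbers stand for stronger inhibition and higher numbers for weaker inhibition), compound 1 gives 3870 nM. Among the measured compounds shown here, the only other measured member is compound 2, `Cc1ccc(S(=O)(=O)Nc2ccc(NC(=O)CCCCCCNC(=O)C(O)(O)C(F)(F)F)cc2)cc1`, which in this assay gives 17200 nM. Compound 1 therefore holds the lower of the two numbers, and its gap to compound 2 lies beyond the usual scatter, so on this read-out compound 1 is the stronger inhibitor of the pair. For the measured compounds named here, compound 2 differs from compound 1 in several places at once, so no single-change step between measured compounds is available to show what one substituent on the aromatic ring contributes.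

Compound 3, `COc1cccc(NC(=O)CCCCCCNC(=O)C(O)(O)C(F)(F)F)c1`, is the next member awaiting measurement. It differs from compound 1 as follows: hydrogen in place of methoxy on an aromatic carbon. Nothing measured speaks directly to this change. The expectation is a modest step, a 1.4-fold higher number from compound 1 to compound 3 (0.15 log units; within the scatter), toward a somewhat higher number, not clearly beyond the scatter. Compound 3 is estimated at 5500 nM, within a range from 2000 nM to 15000 nM, and the notes resume once the number is known.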

Compound 3, half-maximal inhibitory concentration: 6110 nM
The estimate for compound 3 lay 1.1-fold (0.05 log units) below the measured number; the measured number falls inside the stated range.
By their numbers in this assay, from the lowest: compounds 1 and 3 (each within the scatter of the next); then compound 2.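

In this assay, hydrogen in place of methoxy on an aromatic carbon, ortho to a large group and para to a methoxy group, gives a 1.6-fold higher number from compound 1 to compound 3 (0.20 log units; within the scatter), the first single-change step available in this series. On this read-out, compounds 1 and 3 cannot be told apart, so the methoxy group at this position is not shown to matter for the number, and one methoxy group on the ring of the shared core is enough to stay level with compound 1. This rests on a single pair, and no independent measurement bears on this step or offers an account of it.

Still open, as far as these compounds go, is whether a different group at this position, such as an amine, a hydroxyl group or a fluorine atom, would separate from compound 1 by more than the scatter. Also open, from the compounds shown here alone, are whether the remaining methoxy group can give way to hydrogen in the same manner, and whether a longer chain in the shared core would shift the number at all.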